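Changing the Tail Amine: Compound 2 to Compound 3

The source may report more compounds than this note shows. Statements on the series, on what has been measured and on what is new or still open speak of the compounds shown alone.

Compound 1 `COc1cc2nccc(Oc3ccc(NC(=O)c4ncc(-c5ccc(F)cc5)o4)cc3)c2cc1OC`: in a functional assay on HT-29 cells (Homo sapiens) for antiproliferative activity, read by MTT assay, with a stated time of 72 h (on this read-out higher numbers stand for weaker inhibition and lower numbers for stronger inhibition), compound 1 reports only a limit, > 100000 nM.
Compound 2 `COc1cc2c(Oc3ccc(NC(=O)C4(c5nnc(-c6ccc(F)cc6)o5)CC4)cc3F)ccnc2cc1OCCCN1CCN(C)CC1`: in this assay compound 2 gives 1050 nM.

Among the compounds with values here, compound 2 holds the only real number in this set. Compound 1 sits at a limit of the assay, (the limit of > 100000 nM in this assay, at which 1 of the 2 values shown sits). Compound 3 `COc1cc2c(Oc3ccc(NC(=O)C4(c5nnc(-c6ccc(F)cc6)o5)CC4)cc3F)ccnc2cc1OCCCN1CCCC1` differs from compound 2 in one place: pyrrolidin-1-yl in place of 4-methylpiperazin-1-yl on a saturated chain carbon, three bonds along the chain from an oxygen on an aromatic ring. Within the data shown here, no measured pair differs in just this way, so the size of the step is uncertain. The step is expected to stay within the usual scatter, with no clear direction, a 1.1-fold lower number from compound 2 to compound 3 (0.02 log units; within the scatter). Compound 3 is therefore estimated at 1000 nM, most likely between 400 nM and 3000 nM.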

Compound 3, half-maximal inhibitory concentration: 779 nM
Compound 3: the middle estimate sits 1.3-fold (0.11 log units) above what was measured; low and high end bracket the measured number.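

In this assay, within the data shown here, pyrrolidin-1-yl in place of 4-methylpiperazin-1-yl gives a 1.3-fold lower number from compound 2 to compound 3 (0.13 log units; within the scatter) and so provides the first comparison of compounds differing in one place. At this place on the chain, a six-membered ring with 2 hetero atoms and a five-membered ring with 1 hetero atom read alike. No measurement shown bears on the reason for this. As far as these compounds go, whether morpholin-4-yl, an open-chain dimethylamino group or a longer chain would also read alike remains open.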